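Ethyl in Place of Trifluoromethyl: Expecting Recovered Activity

A few compounds are considered here, and "the series" means these few. Any claim that something is new, unique, unknown or untested is made for them only; others in the source may bear on it.

Of the compounds shown here, three built on one shared core have been tested in a functional assay on ileum (strain Hartley) for agonist activity at 5-hydroxytryptamine receptor 3A (Cavia porcellus); a lower number here means a less potent compound, a higher number a more potent compound, by a factor of ten per unit of this negative logarithm. Compound 1 `Cc1cccc2nc(N3CCN(C)CC3)oc12` gives 5.48, and compound 3 `CN1CCN(c2nc3cccc(Cl)c3o2)CC1` gives 5.5; the step of a number 0.02 log units higher from compound 1 to compound 3 (within the scatter) stays within the usual scatter. Compound 2 `CN1CCN(c2nc3cc(C(F)(F)F)ccc3o2)CC1` gives only < 4, which is a limit of the assay rather than a number, a situation noted in the limit of < 4 in this assay, at which 1 of the 3 values shown sits. Compound 4 `CCc1ccc2oc(N3CCN(C)CC3)nc2c1` differs from compound 2 by ethyl in place of trifluoromethyl on an aromatic carbon. Going by the values given here, the single measured step exchanges methyl for chloro and leaves the group changed here untouched, so no measured step shows what this swap does. Because compound 1 carrying methyl gives 5.48 and compound 3 carrying chloro gives 5.5, compound 4 is expected to show a step of a number at least 0.80 log units higher from compound 2 to compound 4 (beyond the scatter) in this assay. Compound 4 is therefore estimated at 4.8, within 3.9 to 5.6.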

Compound 4, negative logarithm of the half-maximal effective concentration: < 4
Compound 4: only a limit was reported; the forecaster's own chance of this, stated with the estimate: 25%; middle value at least 0.80 log units away from the limit.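

Compound 2 and compound 4 each give only a limit of the assay rather than a number, so no step between them can be read: the limit of < 4 in this assay, at which 2 of the 4 values shown sit.

The compounds shown leave open whether ethyl in place of trifluoromethyl changes potency at all in this assay.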